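Swapping the Sulfonyl Aryl Group for Benzyl

A few compounds are considered here, and "the series" means these few. Any claim that something is new, unique, unknown or untested is made for them only; others in the source may bear on it.

Of the compounds shown here, three sharing one core have been tested in an ADME assay on BJ cells (Homo sapiens) for antiproliferative activity, with a stated time of 72 h; a lower number here means that less compound is needed, a higher number that more compound is needed for the effect. Compound 1 `COC(=O)c1cc(=O)c2c(OC)cc(OC)cc2n1S(=O)(=O)c1ccc(C)cc1` gives 139000 nM in this assay. Compound 2 `COc1ccc(-c2cc(=O)c3c(OC)cc(OC)cc3n2S(=O)(=O)c2ccc(C)c([N+](=O)[O-])c2)cc1` reaches only a limit of the assay, > 51700 nM. Compound 3 `COc1ccc(-c2cc(=O)c3c(OC)cc(OC)cc3n2S(=O)(=O)c2c(C(C)C)cc(C(C)C)cc2C(C)C)cc1` likewise ends at a limit, > 341000 nM. Going by the values given here, compound 2 therefore stands at a limit, and one further value among the three is a limit as well; no measured step connects compound 2 to compound 1 or to compound 3, since each of those pairs differs in more than one place.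

Compound 4 `COc1ccc(-c2cc(=O)c3c(OC)cc(OC)cc3n2S(=O)(=O)Cc2ccccc2)cc1` has not yet been measured. It differs from compound 2 in a single place: benzyl in place of 4-methyl-3-nitrophenyl on a sulfonyl sulfur. With both sulfonyl-aryl analogues of the 4-methoxyphenyl series sitting at limits, the limit of > 51700 nM in this assay, at which 1 of the 3 values shown sits, and (the limit of > 341000 nM in this assay, at which 1 of the 3 values shown sits), and compound 1 showing only weak activity, there is no footing in this assay to expect the benzyl group to bring a large gain, and the author expects a step from compound 2 to compound 4 of a step that the limit leaves unreadable from compound 2 to compound 4, within or near the scatter. Compound 4 is estimated at 80000 nM, with a range from 20000 nM to 400000 nM, and the result may well again be only a limit.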

Compound 4, half-maximal effective concentration: > 34400 nM
Compound 4: no number, only a limit (the forecaster's own chance of this, stated with the estimate: 60%); the middle value does not contradict the limit.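

In this assay compound 4 ends at a limit of the assay, > 34400 nM. Compound 2 also stands at a limit, > 51700 nM. Going by these compounds alone, as both values are limits, no step between compound 2 and compound 4 can be read. The compounds shown leave open whether benzyl in place of 4-methyl-3-nitrophenyl on a sulfonyl sulfur changes the concentration needed at all.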